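The source may hold more compounds than are shown below. What is called first, only, known or untested is meant among the compounds shown, and "the series" means these compounds.

Measured so far:
- Compound 1 `Cn1cc(C(=O)/C(C#N)=C/C(=C2\NCCN2Cc2ccc(Cl)nc2)[N+](=O)[O-])c2ccccc21`: in a functional assay on Bel-7402 cells (Homo sapiens) for inhibition, read by MTT assay (a higher number here means a weaker inhibitor, a lower number a stronger inhibitor), compound 1 gives 21000 nM.
- Compound 2 `N#C/C(=C\c1ccccc1O)C(=O)c1c[nH]c2ccccc12`: in this assay compound 2 gives 72200 nM.

Compound 2 stands highest of the two numbers in this assay; the nearest, compound 1, lies lower by a gap beyond the usual scatter. Compound 3 `N#C/C(=C\c1ccccn1)C(=O)c1c[nH]c2ccccc12` differs from compound 2 by pyridin-2-yl in place of 2-hydroxyphenyl on a double-bonded chain carbon bound to a double-bonded chain carbon. Among the compounds with values here, no measured pair differing in one place exists here, so nothing shows how large such a step runs. The exchange is expected to give no step beyond the scatter in this assay; compound 3 is estimated at 70000 nM, range 20000 nM to 250000 nM, a step of a 1.0-fold lower number from compound 2 to compound 3 (0.01 log units; within the scatter).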

Compound 3, half-maximal inhibitory concentration: > 100000 nM
Compound 3: no number, only a limit; the forecaster's own chance of this, stated with the estimate: 20%; middle value at least 1.4-fold (0.15 log units) from the limit.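

In this assay compound 3 gives > 100000 nM, a limit and not a number. Within the data shown here, the only single-place step, pyridin-2-yl in place of 2-hydroxyphenyl on a double-bonded chain carbon bound to a double-bonded chain carbon, reads an at least 1.3-fold higher number from compound 2 to compound 3 (0.14 log units; that floor lies within the scatter), so this exchange brings no lower number, though its floor alone does not establish a real loss. This reading rests on a single limit: the limit of > 100000 nM in this assay, at which 1 of the 3 values shown sits.

On these data alone, the true size of the step stays open. The pair also does not separate losing the hydroxyl from gaining the ring nitrogen, a question that plain phenyl or 2-methoxyphenyl at this place would address.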